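The source may report more compounds than this note shows. Statements on the series, on what has been measured and on what is new or still open speak of the compounds shown alone.

Measured in a functional assay on PANC-1 cells (Homo sapiens) for cytotoxicity, read by WST assay, with a stated time of 24 h; a lower number here means a stronger inhibitor, a higher number a weaker inhibitor:
- compound 1 `O=C(/C=C/CCCCCCc1ccccc1)N[C@H]1CC[C@H](O)CC1`: > 100000 nM (a limit)
- compound 2 `O=C(CCCCCCCCc1ccc(C(F)(F)F)cc1)N1CCCCC1`: 54000 nM
- compound 3 `O=C(CCCCCCCCc1ccc(O)cc1)N1CCCCC1`: > 100000 nM (a limit)

Compound 3 has no true number here, only the limit > 100000 nM. It shares that ceiling with one other compound: the limit of > 100000 nM in this assay, at which 2 of the 3 values shown sit. Compound 4 `O=C(CCCCCCCCc1ccccc1Cl)N1CCCCC1` changes the group on the end of the chain: 2-chlorophenyl in place of 4-hydroxyphenyl on a saturated chain carbon, eight bonds along the chain from a carbonyl carbon. That is 2-chlorophenyl in place of 4-hydroxyphenyl.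

For the measured compounds named here, one measured step bears on this: an at least 1.8-fold higher number from compound 2 to compound 3 (0.26 log units; that floor lies within the scatter), with hydroxy in place of trifluoromethyl on an aromatic carbon. It is only a floor, so it is a weak guide. Compound 4 also lacks the hydroxy, so it is expected to fall closer to compound 2 at 54000 nM. In this assay, the expected change is an at least 1.6-fold lower number from compound 3 to compound 4 (0.22 log units; that floor lies within the scatter), a modest move to a lower number that may not clear the scatter. For compound 4 the estimate is 60000 nM, with an expected range from 30000 nM to 100000 nM.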

Compound 4, half-maximal inhibitory concentration: > 100000 nM
Compound 4: no number, only a limit (the forecaster's own chance of this, stated with the estimate: 35%); middle value at least 1.6-fold (0.22 log units) from the limit.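

Compound 4 gives only a limit (> 100000 nM). For the compounds shown here, compound 3 also has only a limit, so no step between these two compounds can be read. From the compounds shown here alone, whether 2-chlorophenyl or 4-hydroxyphenyl at the end of the chain gives the lower number remains open.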